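This account rests on a few compounds, and the source may have more. Where it says the series, first, only, none or still open, it means among the compounds named here.

Compound 2 `COC(=O)c1ccc(C2SCC(=O)N2c2ccc(N3CCN(S(=O)(=O)c4cc(Cl)ccc4Cl)CC3)cn2)c(OC)c1` and compound 1 `COC(=O)c1ccc(C2SCC(=O)N2c2ccc(N3CCN(S(=O)(=O)c4ccccc4)CC3)cn2)c(OC)c1` share one core and differ only in the aryl group on the sulfonyl sulfur. In a functional assay on NALM-6 cells (Homo sapiens) for antiproliferative activity, read by MTT assay and trypan blue exclusion, with a stated time of 72 h (a higher number here means a weaker inhibitor, a lower number a stronger inhibitor), compound 1 gives 48400 nM, and in this assay compound 2 gives 27400 nM. For the measured compounds named here, the step of a 1.8-fold lower number from compound 1 to compound 2 (0.25 log units; within the scatter) is the only measured step, and it sits within the scatter, so compound 2 holds the lowest of the two numbers without standing apart from compound 1.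

Compound 3 `COC(=O)c1ccc(C2SCC(=O)N2c2ccc(N3CCNCC3)cn2)c(OC)c1` is the next compound. Its change from compound 2 is hydrogen in place of (2,5-dichlorophenyl)sulfonyl on an amine nitrogen in a ring. Going by the values given here, no measured step bears on this change: the single step between compound 1 and compound 2 exchanged one aryl group for another on the sulfonyl sulfur and left the (2,5-dichlorophenyl)sulfonyl group in place, whereas here the whole group is removed and only a hydrogen remains. The expected step of a 2.6-fold higher number from compound 2 to compound 3 (0.41 log units; beyond the scatter) is therefore uncertain, and a weaker inhibitor is taken as the more likely outcome, since the two measured compounds both carry the full group. Compound 3 is estimated at 70000 nM, within a range from 20000 nM to 250000 nM.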

Compound 3, half-maximal inhibitory concentration: 9710 nM
Compound 3: the middle estimate sits 7.2-fold (0.86 log units) above what was measured; measured number below the stated range.
By their numbers in this assay, from the lowest: compound 3; then compounds 2 and 1 (each within the scatter of the next).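

Taking the whole sulfonyl group off this ring nitrogen is the first change here to move the number beyond the scatter in this assay: hydrogen in place of (2,5-dichlorophenyl)sulfonyl gives a 2.8-fold lower number from compound 2 to compound 3 (0.45 log units; beyond the scatter), and hydrogen in place of phenylsulfonyl gives a 5.0-fold lower number from compound 1 to compound 3 (0.70 log units; beyond the scatter). Both steps run the same way and both are modest, so among these three compounds an arylsulfonyl group on this nitrogen is not required for activity, and compound 3, with only hydrogen there, is the strongest inhibitor. Nothing available explains why losing the group lowers the number.

The compounds shown leave open whether the sulfonyl link or the aryl ring accounts for the difference, and how a small group on the same nitrogen, such as a methyl or an acetyl, would compare with hydrogen. They also leave open whether the same step would hold if a carboxylic acid stood in place of the methyl ester on the shared core.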